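A few compounds are considered here, and "the series" means these few. Any claim that something is new, unique, unknown or untested is made for them only; others in the source may bear on it.

Three compounds that share a core carrying a long chain have been tested in a functional assay on PLC-PRF-5 cells (Homo sapiens) for inhibition, read by MTT assay, with a stated time of 72 h; a lower number here means a stronger inhibitor, a higher number a weaker inhibitor. Compound 1 `Nc1ncnc2c1c(-c1cnc3[nH]ccc3c1)nn2CCCCCCCCC(=O)NO` gives 14900 nM in this assay. Compound 3 `Nc1ncnc2c1c(-c1cnc3[nH]ccc3c1)nn2CCCCCCCCCC(=O)NO` gives 34200 nM in this assay. For compound 2 `Nc1nc2cc(-c3nn(CCCCCCCCCC(=O)NO)c4ncnc(N)c34)ccc2o1` the read-out reaches only a limit of the assay, > 100000 nM in this assay, which is the limit of > 100000 nM in this assay, at which 1 of the 3 values shown sits. Lengthening the chain gave a 2.3-fold higher number from compound 1 to compound 3 (0.36 log units; beyond the scatter), and the exchange on the aromatic carbon gave an at least 2.9-fold lower number from compound 2 to compound 3 (0.46 log units; beyond the scatter).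

Compound 4 `Nc1nc2cc(-c3nn(CCCCCCCCC(=O)NO)c4ncnc(N)c34)ccc2o1` is compound 2 with a shorter chain: hydroxycarbamoyl in place of (hydroxycarbamoyl)methyl on a saturated chain carbon, eight bonds along the chain from an aromatic nitrogen. Among the compounds with values here, the only measured step of the same kind is a 2.3-fold higher number from compound 1 to compound 3 (0.36 log units; beyond the scatter), read here in the opposite direction, so a modestly lower number is expected for compound 4 in this assay. Compound 2 stands only at a limit, so the starting point itself is uncertain and the result may again be a limit. The step from compound 2 to compound 4 is expected as an at least 1.1-fold lower number from compound 2 to compound 4 (0.04 log units; that floor lies within the scatter). Compound 4 is expected to give 90000 nM, within the range 40000 nM to 300000 nM.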

Compound 4, half-maximal inhibitory concentration: 24000 nM
Compound 4: middle estimate off by 3.8-fold (0.57 log units), on the high side; the whole stated range lies above it.
By their numbers in this assay, from the lowest: compounds 1, 4 and 3 (each within the scatter of the next, the first and the last beyond it). At a limit, above all of these: compound 2.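

In this assay, replacing (hydroxycarbamoyl)methyl with hydroxycarbamoyl gives an at least 4.1-fold lower number from compound 2 to compound 4 (0.61 log units; beyond the scatter), so the shorter chain goes with the lower number on a second core as well: the same change on two cores in this assay, a 2.3-fold higher number (0.36 log units; beyond the scatter) from compound 1 to compound 3 and an at least 4.1-fold higher number (0.61 log units; beyond the scatter) from compound 4 to compound 2; the limit leaves it open whether they differ

With the shorter chain, the exchange on the aromatic carbon gives a 1.6-fold higher number from compound 1 to compound 4 (0.21 log units; within the scatter), so at this chain length the two aromatic groups cannot be told apart, although with the longer chain the step lay beyond the scatter: the same change on two cores in this assay, an at least 2.9-fold lower number (0.46 log units; beyond the scatter) from compound 2 to compound 3 and a 1.6-fold lower number (0.21 log units; within the scatter) from compound 4 to compound 1; the limit leaves it open whether they differ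

Compound 2 remains at a limit of the assay, so the full size of its steps stays unknown: the limit of > 100000 nM in this assay, at which 1 of the 4 values shown sits.

The compounds shown leave open how a chain shorter than that of compound 1 and compound 4 would read. They also leave open whether a carboxylic acid at the chain end would keep the numbers seen with hydroxycarbamoyl.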